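This account rests on a few compounds, and the source may have more. Where it says the series, first, only, none or still open, it means among the compounds named here.

The measured compounds:
Compound 1 `COc1cccc(Nc2nc(N)c(C(=O)c3ccccc3)s2)c1`: 3200 nM
Compound 2 `COc1cc(C(=O)c2sc(Nc3ccc(C)cc3)nc2N)cc(OC)c1OC`: 86 nM

In a functional assay on HeLa cells (Homo sapiens) for antiproliferative activity, read by cell counting, with a stated time of 2 days (a lower number here means a stronger inhibitor, a higher number a weaker inhibitor), compound 1 gives 3200 nM, while compound 2 gives 86 nM. For the measured compounds named here, of the two numbers on hand, compound 2 has the lower one, and its only neighbour, compound 1, stands far higher, a gap that lies well beyond the scatter of the assay. The two compounds differ in several places at once, so no single change can be read off between them.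

Compound 3 `COc1cc(C(=O)c2sc(Nc3ccc(Cl)cc3)nc2N)cc(OC)c1OC` keeps the whole of compound 2 except for one change: chloro in place of methyl on an aromatic carbon. Going by the values given here, no pair of measured compounds isolates this change, so nothing in the data shows how this assay responds to it. The author therefore expects the step of a 1.1-fold lower number from compound 2 to compound 3 (0.06 log units; within the scatter) to be small, with no direction beyond the scatter. Compound 3 is accordingly estimated at 75 nM, with a range from 25 nM to 250 nM.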

Compound 3, half-maximal inhibitory concentration: 180 nM
For compound 3 the middle estimate is 2.4-fold (0.38 log units) below the measured one, within the range that was stated.
By their numbers in this assay, from the lowest: compound 2; then compound 3; then compound 1.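

In this assay, for the compounds shown here, this pair isolates the position for the first time, and it shows that the assay responds to chloro in place of methyl on an aromatic carbon, para to a large group, with a 2.1-fold higher number from compound 2 to compound 3 (0.32 log units; beyond the scatter). The direction favours the 4-methylphenyl group over the 4-chlorophenyl group, though the step is modest, and it arises from an exchange that leaves the counts of heavy atoms, hydrogen-bond donors and hydrogen-bond acceptors unchanged, with no net charge on either group. The data at hand give no reason for this direction.

On these data alone, what a fluoro, a methoxy or an amine would do on the same aromatic carbon remains open, since the comparison here rests on methyl and chloro alone. Also open, as far as these compounds go, is whether the same step would appear with the plain benzoyl group of compound 1 in place of the trimethoxybenzoyl group.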